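Lengthening the alkyl chain on compound 3

The source may report more compounds than this note shows. Statements on the series, on what has been measured and on what is new or still open speak of the compounds shown alone.

Measured so far in a functional assay on MCF7 cells (Homo sapiens) for inhibition, read by fluorescence, with a stated time of 72 h; a higher number here means a weaker inhibitor of growth, a lower number a stronger inhibitor of growth:
Compound 1 `Cc1nc(C2CC2)cc2nn(-c3ccccc3)cc12`: 63500 nM
Compound 2 `CCCCCc1cc2nn(-c3ccccc3)cc2cn1`: 11800 nM
Compound 3 `CCCCc1cc2nn(-c3ccccc3)cc2c(C)n1`: 11100 nM

Compound 3 has the lowest of the three numbers in this assay, but its gap to compound 2 lies within the scatter, so the two cannot be ordered; only compound 1 stands clearly apart. For the measured compounds named here, the one single-point step recorded is a 5.7-fold lower number from compound 1 to compound 3 (0.76 log units; beyond the scatter), a modest change for exchanging the ring on that aromatic carbon for a chain.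

Compound 4 `CCCCCc1cc2nn(-c3ccccc3)cc2c(C)n1` is not yet measured. It differs from compound 3 by methyl in place of hydrogen on a saturated chain carbon, four bonds along the chain from an aromatic carbon. Going by the values given here, no measured pair isolates this addition. Among the compounds with values here, compound 2 carries a chain of the same length as compound 4 but differs from compound 3 in more than one place, so no single step links them; its value and that of compound 3 sit within the scatter of each other. A small step is therefore expected, a 1.1-fold lower number from compound 3 to compound 4 (0.05 log units; within the scatter), with no direction beyond the scatter. The estimate for compound 4 in this assay is 10000 nM, ranging from 4500 nM to 22000 nM.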

Compound 4, concentration for 50% growth inhibition: 17000 nM
For compound 4 the middle estimate is 1.7-fold (0.23 log units) below the measured one; low and high end bracket the measured number.
By their numbers in this assay, from the lowest: compounds 3, 2 and 4 (each within the scatter of the next); then compound 1.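

Going from butyl to pentyl at this position does not resolve in this assay: the added methyl, on a saturated chain carbon four bonds along the chain from an aromatic carbon, gives only a small shift (a 1.5-fold higher number from compound 3 to compound 4 (0.19 log units; within the scatter)), so the chain length tried here can be changed by this much without a change that can be told from the scatter. With the pentyl chain in place, methyl in place of hydrogen on an aromatic carbon is also unresolved (a 1.4-fold higher number from compound 2 to compound 4 (0.16 log units; within the scatter)), while pentyl keeps a gap beyond the scatter from the cyclopropyl of compound 1 (a 3.7-fold lower number from compound 1 to compound 4 (0.57 log units; beyond the scatter)). No evidence is available to explain any of these steps.

On these data alone, whether a longer chain would move the number beyond the scatter remains open. So does the effect of an amine or a carboxylic acid carried on the chain.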